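The source may hold more compounds than are shown below. What is called first, only, known or untested is meant among the compounds shown, and "the series" means these compounds.

Measured so far:
compound 1, `C[C@H]1[C@H](O)[C@@H](CO)O[C@H]1n1cc(Br)c(=O)[nH]c1=O`, gives > 100 ug/mL;
compound 2, `C[C@H]1[C@H](O)[C@@H](CO)O[C@H]1n1cc(I)c(=O)[nH]c1=O`, gives > 100 ug/mL;
compound 3, `C[C@H]1[C@H](O)[C@@H](CO)O[C@H]1n1cc(Br)c(N)nc1=O`, gives > 100 ug/mL.

All three readings come from a functional assay on NC-37 cells (Homo sapiens) for cytotoxicity; a higher number here means that more compound is tolerated, a lower number that less compound is tolerated. For compound 1 the value > 100 ug/mL is a limit of the assay and not a number. For compound 2 the value > 100 ug/mL is likewise a limit. For compound 3 the value > 100 ug/mL is a limit as well. The change from compound 1 to compound 2 is iodo in place of bromo on an aromatic carbon, and the step that the two limits leave unreadable from compound 1 to compound 2 cannot be read because of the limit of > 100 ug/mL in this assay, at which 3 of the 3 values shown sit. How the core of compound 3 differs from that of compound 1 is not broken down here.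

Compound 4, `C[C@H]1[C@H](O)[C@@H](CO)O[C@H]1n1cc(I)c(N)nc1=O`, is to be measured in this assay. It differs from compound 3 by iodo in place of bromo on an aromatic carbon. Around the place, the ring carbon is ortho to an amino group (1 heavy atom) in compound 3, whereas in compound 1 it is ortho to a group of 1 heavy atom, so this is the same kind of change, not the same one. The expected step is a step that the limit leaves unreadable from compound 3 to compound 4, resting on the unreadable step that the two limits leave unreadable from compound 1 to compound 2, where both values sit at the limit. Compound 4 is therefore estimated at 150 ug/mL, most likely again reported only as a limit, with a range from 60 ug/mL to 400 ug/mL.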

Compound 4, half-maximal cytotoxic concentration: > 100 ug/mL
Compound 4 was reported as a limit; the forecaster's own chance of this, stated with the estimate: 85%; the middle value does not contradict the limit.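

The step from compound 3 to compound 4 cannot be read, and no new size can be taken from this result, because both compounds sit at the same limit: the limit of > 100 ug/mL in this assay, at which 4 of the 4 values shown sit.

The compounds shown leave open how far apart the four really lie in this assay, and whether iodo in place of bromo on an aromatic carbon changes the tolerated concentration at all.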